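Alkoxy variation on the shared core in receptor binding

The source may hold more compounds than are shown below. What is called first, only, known or untested is meant among the compounds shown, and "the series" means these compounds.

Measured compounds, each in an assay on cells with melanin-concentrating hormone receptor 1 (Homo sapiens) as the target, read by radioligand binding; on this read-out higher numbers stand for weaker inhibition and lower numbers for stronger inhibition:
Compound 1 `CCOCC(C)Oc1cccc2ccc(N)nc12` gives 1070 nM.
Compound 2 `CC(C)=CCOc1cccc2ccc(N)nc12` gives > 2000 nM, which is a limit of the assay and not a number.
Compound 3 `CCCCCOc1cccc2ccc(N)nc12` gives 580 nM.

Compound 3 holds the lowest of the two numbers in this assay; its nearest neighbour is compound 1, and the step of a 1.8-fold lower number from compound 1 to compound 3 (0.27 log units; within the scatter), so the two cannot be ordered. For compound 2 only the limit of > 2000 nM in this assay, at which 1 of the 3 values shown sits, is known. Among the measured compounds shown here, the step of an at least 3.4-fold lower number from compound 2 to compound 3 (0.53 log units; beyond the scatter) is the one change beyond the scatter in the set.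

Compound 4 `Nc1ccc2cccc(OC3CCC3)c2n1` has not yet been measured. It differs from compound 3 by cyclobutyl in place of pentyl on an oxygen on an aromatic ring. For the measured compounds named here, the steps that bear on it are the two alkoxy changes already seen: a 1.8-fold lower number from compound 1 to compound 3 (0.27 log units; within the scatter) and an at least 3.4-fold lower number from compound 2 to compound 3 (0.53 log units; beyond the scatter). Neither involves a ring, so the move to cyclobutyl is not directly covered. Given that a saturated group on this oxygen was at most modestly better than the unsaturated one, and that compound 1 sits within the scatter of compound 3, a step of no more than modest size is expected, most likely toward a somewhat higher number for the shorter group. The expected step is a 1.5-fold higher number from compound 3 to compound 4 (0.17 log units; within the scatter). For compound 4 in this assay the estimate is 850 nM, with a range from 300 nM to 2500 nM.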

Compound 4, half-maximal inhibitory concentration: > 2000 nM
Compound 4 was reported as a limit; the forecaster's own chance of this, stated with the estimate: 20%; at least 2.3-fold (0.37 log units) between middle value and limit.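

In this assay, cyclobutyl in place of pentyl on the oxygen gives a second change beyond the scatter, an at least 3.4-fold higher number from compound 3 to compound 4 (0.53 log units; beyond the scatter), which shows that a saturated group on this oxygen does not by itself keep the number of compound 3, something the earlier comparison with the unsaturated group of compound 2 could not show. The other readable step, an at least 1.8-fold higher number from compound 1 to compound 4 (0.27 log units; that floor lies within the scatter), has a floor within the scatter and so does not order that pair, while the step joining the two limits cannot be read. Compound 4 is reported as a limit and not a number, the second such value in this small set: the limit of > 2000 nM in this assay, at which 2 of the 4 values shown sit.

Whether the ring or the shorter group accounts for the change stays open, and a straight butyl chain, a hexyl chain, cyclopentyl or cyclohexyl on the same oxygen would be needed to separate the two. Going by these compounds, the order of compound 2 and compound 4 also stays open, as does the response to an amine or a carboxylic acid at the end of a pentyl chain.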